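Replacing the 3-bromothiophen-2-yl group of compound 2

The compounds below may be only part of what the source reports. "The series", "measured", "known", "first", "only" and "open" are said of these compounds alone.

Compound 1 `Cc1ccc2nc(Cl)c(/C=C/C(=O)c3ccc(I)s3)cc2c1` gives 129 nM in a functional assay on HUVEC cells (Homo sapiens), read by BrdU incorporation, with a stated time of 72 h; on this read-out lower numbers stand for stronger inhibition and higher numbers for weaker inhibition
Compound 2 `Cc1ccc2nc(Cl)c(/C=C/C(=O)c3sccc3Br)cc2c1` gives 61.9 nM in this assay

Compound 2 holds the lower of the two numbers. Among the measured compounds shown here, the only measured step is a 2.1-fold lower number from compound 1 to compound 2 (0.32 log units; beyond the scatter), which is modest. Compound 3 `Cc1ccc2nc(Cl)c(/C=C/C(=O)c3ccc(C)s3)cc2c1` has not yet been measured in this assay. Its difference from compound 2 is 5-methylthiophen-2-yl in place of 3-bromothiophen-2-yl on a carbonyl carbon, which places 5-methylthiophen-2-yl in place of 3-bromothiophen-2-yl on a carbonyl carbon. The group entering is numbered like the 5-iodothiophen-2-yl group of compound 1, which gives 129 nM, so that one step is the closest guide available. A modest move toward a higher number in this assay is therefore expected, of about the same size as that step. The expected change is a 1.9-fold higher number from compound 2 to compound 3 (0.29 log units; within the scatter). Compound 3 is estimated at 120 nM, with an expected range from 50 nM to 280 nM.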

Compound 3, half-maximal inhibitory concentration: 128 nM
Compound 3: the middle estimate sits 1.1-fold (0.03 log units) below what was measured; the range from low to high includes it.
By their numbers in this assay, from the lowest: compound 2; then compounds 3 and 1 (each within the scatter of the next).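

In this assay, the step to the 5-methylthiophen-2-yl group gives a 2.1-fold higher number from compound 2 to compound 3 (0.32 log units; beyond the scatter), so compound 2 now stands apart from two differently substituted thiophen-2-yl compounds rather than one. Methyl in place of iodo on an aromatic carbon gives a 1.0-fold lower number from compound 1 to compound 3 (0.00 log units; within the scatter), which shows that this read-out does not separate these two groups at that place. Together, the steps show that a change of this group on the carbonyl carbon can shift the number, while this exchange of methyl and iodo does not. No evidence is at hand that would explain these numbers. Going by these compounds, whether the lower number of compound 2 goes with the bromine itself or with its place on the ring stays open. So does what an amine or a carboxylic acid would give in place of the methyl of compound 3.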